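Dropping the Methyl from Compound 1

This account rests on a few compounds, and the source may have more. Where it says the series, first, only, none or still open, it means among the compounds named here.

Compound 1 `Cc1cnc2sn(-c3ccc(Br)cc3)c(=O)c2c1` is the reference point here. Going by the values given here, in an assay for inhibition of histone acetyltransferase KAT2B (Homo sapiens), read by fluorescence (on this read-out higher numbers stand for weaker inhibition and lower numbers for stronger inhibition), compound 1 gives 2990 nM, the lowest of the three numbers measured so far. Compound 2 `Cc1cnc2sn(-c3ccc(Oc4ccccc4)cc3)c(=O)c2c1` gives 12900 nM, and the step of a 4.3-fold higher number from compound 1 to compound 2 (0.63 log units; beyond the scatter) shows that swapping bromo for phenoxy weakens inhibition. Compound 3 `O=c1c2cccnc2sn1Cc1ccc(F)c(F)c1` gives 101000 nM, a much higher number, but it differs from compound 1 in more than one place, so it does not isolate any single change.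

Compound 4 `O=c1c2cccnc2sn1-c1ccc(Br)cc1` differs from compound 1 by hydrogen in place of methyl on an aromatic carbon on the shared core. Among the compounds with values here, none of the measured steps bears directly on this change: the one clean step, from compound 1 to compound 2, concerns the bromo group on the other ring, not the methyl on the core. With no guidance from a matching step, the expectation is that removing a single carbon changes the number little, perhaps a mild weakening, so the step of a 1.5-fold higher number from compound 1 to compound 4 (0.18 log units; within the scatter) is estimated to stay near the scatter. Compound 4 is therefore expected to give about 4500 nM, with a plausible range from 1500 nM to 14000 nM.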

Compound 4, half-maximal inhibitory concentration: 4430 nM
Compound 4: the middle estimate sits 1.0-fold (0.01 log units) above what was measured; the measured number falls inside the stated range.
By their numbers in this assay, from the lowest: compounds 1 and 4 (each within the scatter of the next); then compound 2; then compound 3.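

Going by these compounds alone, this is the first step that tests the methyl on the shared core, as the one earlier clean step changed the bromo group instead. In this assay, hydrogen in place of methyl gives a 1.5-fold higher number from compound 1 to compound 4 (0.17 log units; within the scatter), so compounds 1 and 4 cannot be told apart on this read-out. At this position on the six-membered aromatic ring with 1 nitrogen, the methyl is therefore not needed for the inhibition seen with the bromo-bearing compounds, and no measurement available here accounts for this result.

On these data alone, whether an ethyl, a methoxy, an amine or a carboxylic acid at the same position would shift the number remains open. It is also unknown whether removing the methyl would make as little difference in compound 2, which carries phenoxy rather than bromo.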